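Methylating a Ring Amide Nitrogen: From Six-Membered to Five-Membered Core

The source may report more compounds than this note shows. Statements on the series, on what has been measured and on what is new or still open speak of the compounds shown alone.

Of the compounds shown here, three have been tested in a functional assay on the whole organism with Mus musculus as the target; a lower number here means that less compound is needed, a higher number that more compound is needed for the effect. Compound 1 `O=C1CC[C@@H](NC(=O)OCc2ccccc2)C(=O)N1` gives 46.9 mg/kg. Compound 2 `CN1C(=O)CC[C@@H](NC(=O)OCc2ccccc2)C1=O`, which carries methyl in place of hydrogen on an amide-type nitrogen in a ring, gives 24.4 mg/kg; the step of a 1.9-fold lower number from compound 1 to compound 2 (0.28 log units; within the scatter) is small. Compound 3 `O=C1C[C@@H](NC(=O)OCc2ccccc2)C(=O)N1` gives 110 mg/kg, the highest number of the three. How the core of compound 3 differs from that of compound 1 is not broken down here.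

Compound 4 `CN1C(=O)C[C@@H](NC(=O)OCc2ccccc2)C1=O` has not yet been measured in this assay. It differs from compound 3 by methyl in place of hydrogen on an amide-type nitrogen in a ring. Going by the values given here, this is the same kind of change as the one from compound 1 to compound 2, but not the same: in that pair the nitrogen sits in a six-membered non-aromatic ring with 1 nitrogen, here in a five-membered non-aromatic ring with 1 nitrogen. The expectation for the step from compound 3 to compound 4 is a 1.8-fold lower number from compound 3 to compound 4 (0.26 log units; within the scatter), close to the earlier step, because a 1.9-fold lower number from compound 1 to compound 2 (0.28 log units; within the scatter) was small and within the scatter. Compound 4 is therefore estimated at 60 mg/kg, with a likely range from 30 mg/kg to 130 mg/kg.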

Compound 4, dose for half-maximal effect: 82.5 mg/kg
Estimate against measurement, compound 4: 1.4-fold (0.14 log units) below, within the range that was stated.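

In this assay, methyl in place of hydrogen on the amide-type nitrogen of the five-membered ring gives a 1.3-fold lower number from compound 3 to compound 4 (0.12 log units; within the scatter), so on this core too the change stays within the usual scatter. Set side by side, the steps on the two cores cannot be told apart, which is what a change that carries over would look like: the same change on two cores in this assay, a 1.9-fold lower number (0.28 log units; within the scatter) from compound 1 to compound 2 and a 1.3-fold lower number (0.12 log units; within the scatter) from compound 3 to compound 4, 1.4-fold (0.16 log units) apart, within the scatter of two such steps Still, neither step lies beyond the scatter, so these pairs do not show that the methyl itself lowers the dose needed, and two cores make no rule for any other core in the series.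

The compounds shown carry only hydrogen or methyl on this nitrogen, so it remains open what a longer chain such as ethyl, or a chain ending in an amine or a carboxylic acid, would do there. The large group on the ring is also the same in all four compounds, which leaves open whether the small step would hold with a different group in its place.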